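Working notes: from compound 2 to compound 3

A few compounds are considered here, and "the series" means these few. Any claim that something is new, unique, unknown or untested is made for them only; others in the source may bear on it.

Of the compounds shown here, two have been measured in a functional assay for antagonist activity at transient receptor potential cation channel subfamily V member 1 (Rattus norvegicus); on this read-out lower numbers stand for stronger inhibition and higher numbers for weaker inhibition. Compound 1 `N#Cc1ccc(NC(=O)c2ccc(-c3ncccc3C(F)(F)F)cc2)cc1` gives 1300 nM. Compound 2 `CC(C)(C)c1ccc(NC(=O)c2ccc(-c3ccccn3)cc2)cc1` gives 8 nM; this is the lowest of the two numbers, and the gap to compound 1 lies beyond the scatter. Among the compounds with values here, compound 1 and compound 2 differ in more than one place, so no single step between them is defined, and only their two values can be compared. Compound 3 `CC(C)(C)c1ccc(NC(=O)c2ccc(-c3ncccc3NS(=O)(=O)c3ccccc3)cc2)cc1` is not yet measured. It differs from compound 2 in one place: (phenylsulfonyl)amino in place of hydrogen on an aromatic carbon. The entering group sits ortho to a large group, two atoms from the ring nitrogen. Within the data shown here, no measured step covers a change of this kind, so the expectation rests on compound 2 alone. A moderate rise in the number is expected, a 7.5-fold higher number from compound 2 to compound 3 (0.88 log units; beyond the scatter), with wide uncertainty in either direction. Compound 3 is accordingly estimated at 60 nM, within a range of 10 nM to 400 nM.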

Compound 3, half-maximal inhibitory concentration: 166 nM
Compound 3: the middle estimate sits 2.8-fold (0.44 log units) below what was measured, and the stated range covers the measured number.
By their numbers in this assay, from the lowest: compound 2; then compound 3; then compound 1.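

Placing (phenylsulfonyl)amino on this aromatic carbon, ortho to a large group and two atoms from the ring nitrogen, gives in this assay a 21-fold higher number from compound 2 to compound 3 (1.32 log units; beyond the scatter), the first single-place step in the series. The change weakens inhibition without abolishing it: compound 3 still gives 166 nM, so this carbon can carry a substituent of 10 heavy atoms, one aromatic ring included. Nothing available explains the size of this step.

The compounds shown do not separate the contributions of the sulfonyl link and the terminal phenyl ring, which a plain amine or a methylsulfonylamino group at the same carbon would address. Also open, as far as these compounds go, is how smaller groups, such as a methyl or a fluorine, behave at this carbon.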